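The compounds below may be only part of what the source reports. "The series", "measured", "known", "first", "only" and "open" are said of these compounds alone.

Compound 1 `Cc1ccc(CC(CN/C(S)=N/Cc2ccc(NS(C)(=O)=O)cc2)COC(=O)C(C)(C)C)cc1C` gives 29.3 nM in an assay on isolated protein for binding affinity to transient receptor potential cation channel subfamily V member 1 (Rattus norvegicus); on this read-out lower numbers stand for stronger inhibition and higher numbers for weaker inhibition. Compound 2 `CC(=O)Nc1ccc(C/N=C(\S)NCC(COC(=O)C(C)(C)C)Cc2ccc(C)c(C)c2)cc1` gives 1700 nM in this assay, and compound 3 `COc1cc(C/N=C(\S)NCC(COC(=O)C(C)(C)C)Cc2ccc(C)c(C)c2)ccc1NS(C)(=O)=O` gives 49 nM. The only two single-point steps among these three both start from compound 1: a 58-fold higher number from compound 1 to compound 2 (1.76 log units; beyond the scatter), and a 1.7-fold higher number from compound 1 to compound 3 (0.22 log units; within the scatter). Compound 3 thus stands second highest of the three numbers, separated from compound 1 only within the scatter but well apart from compound 2.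

Compound 4 `COc1cc(C/N=C(\S)NCC(COC(=O)C(C)(C)C)Cc2ccc(C(C)(C)C)cc2)ccc1NS(C)(=O)=O` differs from compound 3 by 4-(tert-butyl)phenyl in place of 3,4-dimethylphenyl on a saturated chain carbon, three bonds along the chain from an amine nitrogen and an oxygen next to a carbonyl group. Going by the values given here, no measured step touches this part of the molecule: both known steps alter the substituent on the nitrogen or the carbon of the other aromatic ring, so they bear on the new change only by showing that the core with the sulfonamide-bearing ring tolerates small variation. Among the compounds with values here, with no direct precedent, the author expects for compound 4 a step of about a 1.2-fold lower number from compound 3 to compound 4 (0.09 log units; within the scatter), that is, no change beyond the scatter. The estimated value for compound 4 in this assay is 40 nM, with a range from 12 nM to 130 nM.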

Compound 4, inhibition constant: 25.2 nM
Beside the measured number, compound 4's estimate is 1.6-fold (0.20 log units) above it; the measured number falls inside the stated range.
By their numbers in this assay, from the lowest: compounds 4, 1 and 3 (each within the scatter of the next); then compound 2.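

Going by these compounds alone, compound 3 and compound 4 give the first measured change at the saturated chain carbon, and in this assay the exchange of 3,4-dimethylphenyl for 4-(tert-butyl)phenyl gives a 1.9-fold lower number from compound 3 to compound 4 (0.29 log units; within the scatter). At this position, with the rest of the molecule held constant, one carbon-only aromatic substituent pattern can thus replace the other without a change beyond the scatter. Nothing shown here gives a reason for this outcome.

On these data alone, the pair covers only these two alkyl-substituted phenyl groups, so it remains open how the position would respond to a phenyl ring carrying a carboxylic acid or an amine, or to a cyclohexyl group. As far as these compounds go, it also remains open whether 4-(tert-butyl)phenyl would give the same result alongside the acetyl group of compound 2.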